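The source may hold more compounds than are shown below. What is called first, only, known or untested is meant among the compounds shown, and "the series" means these compounds.

Measured compounds:
- Compound 1, `CC(C)OC(=O)N1CCC(COc2ccc(N3CCN(C(=O)c4ccco4)CC3)nc2)CC1`: 1900 nM
- Compound 2, `COCCS(=O)(=O)N1CCN(c2ccc(OCC3CCN(C(=O)OC(C)C)CC3)cn2)CC1`: 300 nM
- Compound 3, `CCN(CC)S(=O)(=O)N1CCN(c2ccc(OCC3CCN(C(=O)OC(C)C)CC3)cn2)CC1`: 1200 nM

In a functional assay on CHO-K1 cells for agonist activity at Glucose-dependent insulinotropic receptor (Homo sapiens), read by a luciferase reporter, with a stated time of 5 h (a higher number here means that more compound is needed for the effect, a lower number that less compound is needed), compound 1 gives the highest of the three numbers: its nearest neighbour is compound 3, at a 1.6-fold lower number from compound 1 to compound 3 (0.20 log units; within the scatter), and its furthest is compound 2, at a 6.3-fold lower number from compound 1 to compound 2 (0.80 log units; beyond the scatter). Compound 4, `CC(C)OC(=O)N1CCC(COc2ccc(N3CCN(S(=O)(=O)N4CCCCC4)CC3)nc2)CC1`, has not yet been measured. It differs from compound 1 in one place: (piperidin-1-yl)sulfonyl in place of (furan-2-yl)carbonyl on an amine nitrogen in a ring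

Going by the values given here, two measured steps bear on this change, since both replace the same group on the same ring nitrogen with a sulfonyl-bearing group. The step of a 6.3-fold lower number from compound 1 to compound 2 (0.80 log units; beyond the scatter) was modest but beyond the scatter, whereas the step of a 1.6-fold lower number from compound 1 to compound 3 (0.20 log units; within the scatter) stayed within it. Compound 3 carries a diethylsulfamoyl, the closer relative of the (piperidin-1-yl)sulfonyl entering in compound 4, so the smaller of the two steps is the better guide. Compound 4 is therefore expected to give a number somewhat lower than compound 1, but not clearly beyond the scatter. The number expected for compound 4 is estimated at 900 nM, and the expected range for compound 4 runs from 300 nM to 2500 nM. This estimate for compound 4 means an expected step of a 2.1-fold lower number from compound 1 to compound 4 (0.32 log units; beyond the scatter).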

Compound 4, half-maximal effective concentration: 1000 nM
For compound 4 the middle estimate is 1.1-fold (0.05 log units) below the measured one, within the range that was stated.
By their numbers in this assay, from the lowest: compound 2; then compounds 4, 3 and 1 (each within the scatter of the next).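

In this assay, (piperidin-1-yl)sulfonyl on this ring nitrogen cannot be told apart from the (furan-2-yl)carbonyl it replaces, with a 1.9-fold lower number from compound 1 to compound 4 (0.28 log units; within the scatter), and piperidin-1-yl on the sulfonyl sulfur reads the same as diethylamino, with a 1.2-fold lower number from compound 3 to compound 4 (0.08 log units; within the scatter). By contrast, the 2-methoxyethyl group on that sulfur stands clear of piperidin-1-yl, with a 3.3-fold higher number from compound 2 to compound 4 (0.52 log units; beyond the scatter), so it is the sulfonyl partner, and not the sulfonyl alone, that tracks with the lower number among these compounds. Nothing measured here accounts for that gap.

Going by these compounds, it stays open whether the gap follows the ether oxygen of the 2-methoxyethyl group or the carbon attached directly to the sulfur. A plain propyl chain or a morpholin-4-yl on the sulfonyl sulfur would help to separate these two readings.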